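The compounds below may be only part of what the source reports. "The series", "measured", "known", "first", "only" and "open" are said of these compounds alone.

Measured compounds:
- compound 1, `Cc1ccccc1NC(=S)OCCc1ccccn1`: > 100000 nM
- compound 2, `Fc1cccc(NC(=S)OCCc2ccccn2)c1`: >= 100000 nM
- compound 3, `Cc1ccc(NC(=S)OCCc2ccccn2)cc1`: 75000 nM

In an ADME assay on MT4 cells (Homo sapiens) for cytotoxicity, read by MTT assay (on this read-out lower numbers stand for higher toxicity in this test and higher numbers for lower toxicity in this test), compound 3 is the only one of the three to give a number, 75000 nM. For compound 1 the value > 100000 nM is a limit of this assay, not a number (the limit of > 100000 nM in this assay, at which 1 of the 3 values shown sits). For compound 2 the value >= 100000 nM is likewise a limit (the limit of >= 100000 nM in this assay, at which 1 of the 3 values shown sits). Compound 3 therefore stands as the sole measured point, with the other two at the upper edge of what this assay reports.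

Compound 4, `Fc1ccc(NC(=S)OCCc2ccccn2)cc1`, differs from compound 3 by fluoro in place of methyl on an aromatic carbon, para to a large group. Among the measured compounds shown here, no step between measured compounds is available for this change. Given that compound 2, which also carries fluoro on that ring, sits at >= 100000 nM, compound 4 is expected to show a small step upward, if any, from compound 3, of a 1.3-fold higher number from compound 3 to compound 4 (0.12 log units; within the scatter), within or just beyond the scatter. Compound 4 is estimated at 100000 nM, in the range 50000 nM to 200000 nM, with a fair chance that this assay reports only a limit.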

Compound 4, half-maximal cytotoxic concentration: > 100000 nM
Compound 4: no number, only a limit; the forecaster's own chance of this, stated with the estimate: 60%; the middle value sits exactly at the limit.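

In this assay, fluoro in place of methyl on an aromatic carbon, para to a large group, gives an at least 1.3-fold higher number from compound 3 to compound 4 (0.12 log units; that floor lies within the scatter). Among the compounds shown here, this is the first step that can be read at this position, whereas the earlier compounds offered no pair to compare, but it has only a floor and its true size remains unknown. The value for compound 4 is a limit, not a number, and this compound joins those reported in this way: the limit of > 100000 nM in this assay, at which 2 of the 4 values shown sit.

The compounds shown leave open how far the value of compound 4 would lie from that of compound 3 if it could be given as a number. They also leave open whether an amine or a methoxy group at this position would give a number within the range of this assay.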